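This account rests on a few compounds, and the source may have more. Where it says the series, first, only, none or still open, it means among the compounds named here.

Measured so far in a functional assay on HepG2 cells (Homo sapiens) for cytotoxicity, read by MTT assay, with a stated time of 72 h; a higher number here means a weaker inhibitor, a lower number a stronger inhibitor:
- Compound 1 `CNC(=O)c1cc(Oc2ccc(C(=O)/C=C/c3ccc(Cl)cc3Cl)cc2)ccn1`: 11700 nM.
- Compound 2 `CNC(=O)c1cc(Oc2ccc(C(=O)/C=C/c3cccc([N+](=O)[O-])c3)cc2)ccn1`: > 50000 nM, which is a limit and not a number.

Compound 2 therefore stands at the limit of > 50000 nM in this assay, at which 1 of the 2 values shown sits. Compound 3 `CNC(=O)c1cc(Oc2ccc(C(=O)/C=C/c3cccc(Cl)c3Cl)cc2)ccn1` differs from it in one place: 2,3-dichlorophenyl in place of 3-nitrophenyl on a double-bonded chain carbon bound to a double-bonded chain carbon. This puts 2,3-dichlorophenyl in place of 3-nitrophenyl on a double-bonded chain carbon bound to a double-bonded chain carbon. Among the compounds with values here, the one measured step that bears on this is an at least 4.2-fold higher number from compound 1 to compound 2 (0.63 log units; beyond the scatter), where 3-nitrophenyl replaced 2,4-dichlorophenyl. A partial reversal of that step is expected, toward a lower number, landing near compound 1 at 11700 nM. That means an expected at least 3.3-fold lower number from compound 2 to compound 3 (0.52 log units; beyond the scatter). The estimated value for compound 3 is 15000 nM, within a range of 6000 nM to 40000 nM.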

Compound 3, half-maximal inhibitory concentration: > 50000 nM
Compound 3 ended at the assay's limit (the forecaster's own chance of this, stated with the estimate: 15%); at least 3.3-fold (0.52 log units) between middle value and limit.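

In this assay, two groups with the same atoms behave differently at this position: 2,3-dichlorophenyl in place of 2,4-dichlorophenyl gives an at least 4.2-fold higher number from compound 1 to compound 3 (0.63 log units; beyond the scatter). Having two chlorines on this ring is therefore not enough by itself, and where they sit matters. The step between compound 2 and compound 3 cannot be read, because both values are limits: the limit of > 50000 nM in this assay, at which 2 of the 3 values shown sit.

Going by these compounds, how compound 2 and compound 3 truly rank remains open. So does whether 4-chlorophenyl, with a single chlorine, would give a measured number in this place or another limit.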